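The source may report more compounds than this note shows. Statements on the series, on what has been measured and on what is new or still open speak of the compounds shown alone.

Working notes on the series. Among the measured compounds shown here, compound 1 `COc1cc(-c2cc(/C=C/C(=O)c3ccc(N)cc3)[nH]n2)cc(OC)c1OC` stands highest of the two numbers measured so far: in a functional assay on SF-539 cells (Homo sapiens) for cytotoxicity, read by sulforhodamine B assay, with a stated time of 48 h, tested at 1 uM (on this read-out higher numbers stand for a weaker effect at the one concentration tested and lower numbers for a stronger effect), compound 1 gives 69%. For the measured compounds named here, the only other measured member is compound 2 `COc1ccc(-c2cc(/C=C/C(=O)c3cc(OC)c(OC)c(OC)c3)[nH]n2)cc1OC`, which in this assay gives 17%, a number lower by more than the usual scatter. Going by the values given here, compound 1 and compound 2 differ in more than one place, so the pair shows only its two values and supports no single-change step.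

Compound 3 `COc1ccc(C(=O)/C=C/c2cc(-c3cc(OC)c(OC)c(OC)c3)n[nH]2)cc1` is the next member to go into this assay. Against compound 1 it carries methoxy in place of amino on an aromatic carbon, the change sitting on an aromatic carbon of a six-membered aromatic ring of carbon only, para to a large group. Among the compounds with values here, no measured one-place step covers this swap. The expected step from compound 1 to compound 3 in this assay is a number 14 percentage points lower from compound 1 to compound 3 (beyond the scatter), a modest lowering that may well sit within the scatter. Compound 3 is estimated at 55%, with a range from 25% to 90%.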

Compound 3, a percentage reported as activity, at one concentration (the size of the read-out at that concentration, not a potency): 87%
Estimate against measurement, compound 3: 32 percentage points below, within the range that was stated.
By their numbers in this assay, from the lowest: compound 2; then compound 1; then compound 3.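

In this assay, among the compounds shown here, the change from 4-aminophenyl to 4-methoxyphenyl gives the first single-place step: a number 18 percentage points higher from compound 1 to compound 3 (beyond the scatter), a modest step towards a weaker effect at the one concentration tested. The aromatic carbon para to a large group therefore does not accept these two groups equally, with amino giving the stronger effect of the pair on an otherwise unchanged structure. Nothing measured on either group bears on this step, so the data offer no account of it.

A single swap cannot show whether the step follows the loss of amino or the entry of methoxy. Hydroxy, dimethylamino or acetamido at the same place, or a bare hydrogen there, would be needed to separate the two, and whether the step holds on other cores also stays open.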